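Methoxy on the Fused Ring of Compound 2

This account rests on a few compounds, and the source may have more. Where it says the series, first, only, none or still open, it means among the compounds named here.

Compound 2 `Nc1ccccc1NC(=O)c1ccc(CSc2nc3ccccc3[nH]2)cc1` stands second highest of the three numbers in an ADME assay on HMEC cells (Homo sapiens) for cytotoxicity, read by MTT assay; on this read-out lower numbers stand for stronger inhibition and higher numbers for weaker inhibition: compound 2 gives 14000 nM, while compound 1 `Nc1ccccc1NC(=O)c1ccc(CNc2nc3ccccc3[nH]2)cc1` gives 27000 nM, a gap within the scatter, and compound 3 `Nc1ccccc1NC(=O)c1ccc(CSc2nc3ccccc3s2)cc1` gives 3000 nM. For the measured compounds named here, the only single-site step measured, a 4.7-fold lower number from compound 2 to compound 3 (0.67 log units; beyond the scatter), swaps the ring on the sulfur and does not touch the place now altered. Compound 4 `COc1ccc2nc(SCc3ccc(C(=O)Nc4ccccc4N)cc3)[nH]c2c1` differs from compound 2 by methoxy in place of hydrogen on an aromatic carbon. Going by the values given here, no measured step bears on this change, so in this assay a step of no more than the scatter is expected in either direction. For compound 4 the estimate is 14000 nM, between 5000 nM and 40000 nM, meaning no change at the digits printed from compound 2 to compound 4 (within the scatter) is expected.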

Compound 4, half-maximal inhibitory concentration: 10000 nM
The estimate for compound 4 lay 1.4-fold (0.15 log units) above the measured number; the range from low to high includes it.
By their numbers in this assay, from the lowest: compound 3; then compounds 4, 2 and 1 (each within the scatter of the next, the first and the last beyond it).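

In this assay, for the compounds shown here, methoxy in place of hydrogen on this aromatic carbon gives a 1.4-fold lower number from compound 2 to compound 4 (0.15 log units; within the scatter) and so is the first measured change at this place, one that the read-out does not separate from hydrogen. The step stays within the scatter, whereas the ring change on the sulfur went beyond it. No evidence bears on this result. As far as these compounds go, whether another group on this carbon, such as an amine, a carboxylic acid or a longer chain, would move the number beyond the scatter remains open. So does the effect of methoxy on the core of compound 3.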